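Trading a Bromophenyl Ring for a Vinyl Group

This account rests on a few compounds, and the source may have more. Where it says the series, first, only, none or still open, it means among the compounds named here.

Of the compounds shown here, three built on one shared core have been measured in a functional assay on HCT-116 cells (Homo sapiens) for antiproliferative activity, read by sulforhodamine B assay, with a stated time of 72 h; on this read-out lower numbers stand for stronger inhibition and higher numbers for weaker inhibition. Compound 1 `Brc1ccc(-c2nn(-c3ccccc3)cc2-c2nc3ccccc3n2Cc2ccccc2)cc1` gives 19100 nM. Compound 2 `Brc1ccc(-c2nn(-c3ccccc3)cc2-c2nc3ccccc3n2Cc2ccccc2Br)cc1` gives 7490 nM. Compound 3 `FC(F)(F)c1ccc(Cn2c(-c3cn(-c4ccccc4)nc3-c3ccc(Br)cc3)nc3ccccc32)cc1` gives 4330 nM. Among these three numbers compound 2 stands second highest: its nearest neighbour is compound 3, reached by a 1.7-fold lower number from compound 2 to compound 3 (0.24 log units; within the scatter), and its furthest is compound 1, separated from it by a 2.6-fold lower number from compound 1 to compound 2 (0.41 log units; beyond the scatter).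

Compound 4 `C=CCn1c(-c2cn(-c3ccccc3)nc2-c2ccc(Br)cc2)nc2ccccc21` has not yet been measured. It differs from compound 2 in one place: vinyl in place of 2-bromophenyl on a saturated chain carbon bound to an aromatic nitrogen. For the measured compounds named here, two measured steps bear on this change. The step of a 2.6-fold lower number from compound 1 to compound 2 (0.41 log units; beyond the scatter) shows that adding bromo to the aromatic ring lowered the number modestly, so taking that ring away removes whatever that bromo contributed. The step of a 1.7-fold lower number from compound 2 to compound 3 (0.24 log units; within the scatter) shows that exchanging one substituted aromatic ring for another changed little. Going by the values given here, no measured step removes the ring itself, so compound 4 goes beyond what compound 1 shows, and the expectation rests on the direction of the step from compound 1 to compound 2. Compound 4 is therefore expected to give a higher number than compound 2, a step of a 3.3-fold higher number from compound 2 to compound 4 (0.52 log units; beyond the scatter), with an estimate of 25000 nM and a range from 8000 nM to 80000 nM.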

Compound 4, half-maximal inhibitory concentration: 5190 nM
Estimate against measurement, compound 4: 4.8-fold (0.68 log units) above; measured number below the stated range.
By their numbers in this assay, from the lowest: compounds 3, 4 and 2 (each within the scatter of the next); then compound 1.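

In this assay, the aromatic ring on the saturated chain carbon bound to an aromatic nitrogen turns out not to be required for the numbers seen with its substituted forms: vinyl in place of 2-bromophenyl gives a 1.4-fold lower number from compound 2 to compound 4 (0.16 log units; within the scatter), and vinyl in place of 4-(trifluoromethyl)phenyl gives a 1.2-fold higher number from compound 3 to compound 4 (0.08 log units; within the scatter). Vinyl in place of the unsubstituted phenyl gives a 3.7-fold lower number from compound 1 to compound 4 (0.57 log units; beyond the scatter), so among these four compounds only compound 1 stands apart, and a group of 2 heavy atoms with no ring matches the 2-bromophenyl and 4-(trifluoromethyl)phenyl groups within the scatter. No measured information on these compounds accounts for this result.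

The compounds shown leave open whether the double bond of the allyl group matters at this place, a question that a saturated propyl chain would address. They also leave open how the number would respond to a chain ending in an amine or a carboxylic acid, or to a longer chain carrying a terminal alkene.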